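Nitro in place of methylsulfanyl on the aryl ring

A few compounds are considered here, and "the series" means these few. Any claim that something is new, unique, unknown or untested is made for them only; others in the source may bear on it.

Measured compounds in a functional assay on HCT-116 cells (Homo sapiens) for antiproliferative activity, read by MTT assay, with a stated time of 48 h; on this read-out lower numbers stand for stronger inhibition of growth and higher numbers for weaker inhibition of growth:
compound 1 `S=C(Nc1ccccc1)N1N=C(c2ccccc2)CC1c1ccc2c(c1)OCCO2`: 57600 nM
compound 2 `Fc1ccc(C2=NN(C(=S)Nc3ccccc3)C(c3ccc4c(c3)OCCO4)C2)cc1`: 61200 nM
compound 3 `CSc1ccc(C2=NN(C(=S)Nc3ccccc3)C(c3ccc4c(c3)OCCO4)C2)cc1`: 193000 nM

Compound 3 carries the highest number of the three in this assay: a 3.4-fold higher number from compound 1 to compound 3 (0.53 log units; beyond the scatter) and a 3.2-fold higher number from compound 2 to compound 3 (0.50 log units; beyond the scatter), whereas a 1.1-fold higher number from compound 1 to compound 2 (0.03 log units; within the scatter). Compound 4 `O=[N+]([O-])c1ccc(C2=NN(C(=S)Nc3ccccc3)C(c3ccc4c(c3)OCCO4)C2)cc1` differs from compound 3 by nitro in place of methylsulfanyl on an aromatic carbon. Within the data shown here, no measured step covers a nitro group at this position. The two steps that reach compound 3 both raised the number modestly, and the exchange of hydrogen for fluoro at the same carbon stayed within the scatter, so substituents here have moved the number by little or by a modest amount. A step of similar size, direction uncertain, is expected: a 2.1-fold lower number from compound 3 to compound 4 (0.33 log units; beyond the scatter). Compound 4 is therefore estimated at 90000 nM, with a range from 30000 nM to 250000 nM.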

Compound 4, concentration for 50% growth inhibition: > 200000 nM
Compound 4 was reported as a limit; the forecaster's own chance of this, stated with the estimate: 15%; middle value at least 2.2-fold (0.34 log units) away from the limit.
By their numbers in this assay, from the lowest: compounds 1 and 2 (each within the scatter of the next); then compound 3. At a limit, above all of these: compound 4.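

Compound 4 is reported only as a limit, > 200000 nM, in this assay. Nitro is thus a second group at this carbon, after methylsulfanyl, that separates from hydrogen and fluoro: an at least 3.4-fold higher number from compound 1 to compound 4 (0.54 log units; beyond the scatter), and an at least 3.2-fold higher number from compound 2 to compound 4 (0.51 log units; beyond the scatter). Against methylsulfanyl the floor is an at least 1.0-fold higher number from compound 3 to compound 4 (0.01 log units; that floor lies within the scatter), so the order of these two groups cannot be read.

None of the four groups shown at this carbon gives a number beyond the scatter lower than that of compound 1. On these data alone, whether an amine or a carboxylic acid here would do so remains open.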